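Swapping chloro for methoxy in a cytotoxic pair

The source may hold more compounds than are shown below. What is called first, only, known or untested is meant among the compounds shown, and "the series" means these compounds.

In a functional assay on MDA-MB-231 cells (Homo sapiens) for cytotoxicity (on this read-out higher numbers stand for weaker inhibition and lower numbers for stronger inhibition), compound 1 (`COc1ccc(Cn2cc(/C=N\NC(=O)c3c[nH]c4ccccc34)c3ccccc32)cc1`) gives 15100 nM, while compound 2 (`O=C(N/N=C\c1cn(Cc2ccc(Cl)cc2)c2cc(F)ccc12)c1c[nH]c2ccccc12`) gives 5300 nM. Compound 2 therefore holds the lower of the two numbers and is the stronger inhibitor of this pair, by a gap beyond the usual scatter. These two compounds differ in more than one place, so their gap cannot be assigned to any single group.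

Compound 3 (`COc1ccc(Cn2cc(/C=N\NC(=O)c3c[nH]c4ccccc34)c3ccc(F)cc32)cc1`) departs from compound 2 in one place: methoxy in place of chloro on an aromatic carbon, para to a large group, which turns 4-chlorobenzyl into 4-methoxybenzyl (methoxy in place of chloro on an aromatic carbon). Among the compounds with values here, no measured pair shows this swap alone, so the evidence is thin. Within the data shown here, the only pointer is compound 1, which also carries 4-methoxybenzyl and gives 15100 nM. A small move toward weaker inhibition is therefore expected, close to the scatter, and the estimated change is a 1.7-fold higher number from compound 2 to compound 3 (0.23 log units; within the scatter) in this assay. For compound 3 the expected value is 9000 nM, with an estimated range from 3500 nM to 20000 nM.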

Compound 3, half-maximal inhibitory concentration: 71200 nM
For compound 3 the middle estimate is 7.9-fold (0.90 log units) below the measured one; the whole stated range lies below it.
By their numbers in this assay, from the lowest: compound 2; then compound 1; then compound 3.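

In this assay, the chloro position gets its first clean test, and the change from 4-chlorobenzyl to 4-methoxybenzyl on the fluorinated core gives a 13-fold higher number from compound 2 to compound 3 (1.13 log units; beyond the scatter), so the group at this aromatic carbon matters a great deal. With 4-methoxybenzyl held fixed, the other single change, fluoro in place of hydrogen on an aromatic carbon, gives a modest 4.7-fold higher number from compound 1 to compound 3 (0.67 log units; beyond the scatter), which shows that fluoro does not help when methoxy is present, even though compound 2 carries fluoro and has the lowest number of the three. Compound 3 is thus the weakest inhibitor of the set, and the data contain nothing that explains the size or direction of either step.

On these data alone, it remains open whether fluoro would have the same effect alongside 4-chlorobenzyl, since the two changes may not simply add together. It is also unclear where a methyl, a hydroxyl or an amine at this same carbon would fall relative to chloro and methoxy.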